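The compounds below may be only part of what the source reports. "The series", "measured", "known", "first", "only" and "open" are said of these compounds alone.

Measured so far in an ADME assay on the whole organism with Oryza sativa as the target, tested at 10 uM; a lower number here means a stronger effect, a higher number a weaker effect of the compound at the concentration tested:
- compound 1 `Cc1cccc(NC(=O)N[C@H](C)c2ccccc2)c1`: 47%
- compound 2 `Cc1cccc(NC(=O)N[C@@H](C)c2ccccc2)c1`: 100%
- compound 3 `CCc1ccc(NC(=O)N[C@H](C)c2ccccc2)cc1`: 44%

Compound 1 stands second highest of these three numbers. Its nearest neighbour is compound 3, whose value lies within the usual scatter of the value of compound 1, so the two cannot be told apart. Going by the values given here, the furthest is compound 2, and the one step that has been measured leads there: a number 53 percentage points higher from compound 1 to compound 2 (beyond the scatter). What sets the two apart is small on paper, because of the fact that compounds 1 and 2 differ only in the configuration as drawn.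

Compound 4 `CC(C)c1cccc(NC(=O)N[C@H](C)c2ccccc2)c1` is the next candidate. Its change from compound 1 is isopropyl in place of methyl on an aromatic carbon. Among the compounds with values here, no measured step touches the size of a group on that ring, since the only step measured concerns configuration, and compounds 1 and 3 differ in more than one place. What can be said is that compound 1 and compound 3, carrying different small groups on that ring in different places, give values within the scatter of each other. On that basis no step beyond the scatter is expected in this assay, and the estimated step is no change at the digits printed from compound 1 to compound 4 (within the scatter).

Compound 4 is therefore expected to give about 47%, with a range from 25% to 75%.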

Compound 4, a percentage reported as activity, at one concentration (the size of the read-out at that concentration, not a potency): 44%
The estimate for compound 4 lay 3 percentage points above the measured number; measured number inside the range.
By their numbers in this assay, from the lowest: compounds 3, 4 and 1 (each within the scatter of the next); then compound 2.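

In this assay, going by these compounds alone, putting isopropyl in place of methyl on this aromatic carbon gives a number 3 percentage points lower from compound 1 to compound 4 (within the scatter), and this is the first direct look at a larger group at this place, with 3 heavy atoms entering where 1 leaves. The place meta to a large group therefore takes this enlargement without a step beyond the scatter, whereas the only large step shown so far remains the one in configuration, a number 53 percentage points higher from compound 1 to compound 2 (beyond the scatter), so in this small set the stereocentre matters more than the choice between these two groups. Nothing available here explains why the number holds across this change.

The groups shown on this ring are only methyl, ethyl and isopropyl, all made of carbon and hydrogen, so it remains open whether an amine, a carboxylic acid or a longer chain at the same place would also leave the number where it is. Also open, on these data alone, is how isopropyl would behave on the configuration drawn in compound 2, which stands at 100% with methyl.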